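The source may hold more compounds than are shown below. What is called first, only, known or untested is meant among the compounds shown, and "the series" means these compounds.

Compound 1 `Cc1cc(C)cc(SCc2ccc(/C=C/C(=O)Nc3ccccc3N)cc2)c1`: in a functional assay on HCT-116 cells (Homo sapiens) for inhibition, read by CCK-8 assay, with a stated time of 72 h, tested at 2 uM (a lower number here means less inhibition of growth, a higher number more inhibition of growth at the concentration tested), compound 1 gives 7.98%.
Compound 2 `Nc1ccccc1NC(=O)/C=C/c1ccc(CSc2ccc(Cl)cc2)cc1`: compound 2 gives 5.62%.
Compound 3 `Nc1ccccc1NC(=O)c1ccc(CSc2ccc(Cl)cc2)cc1`: compound 3 gives 17.5%.

Compound 1 and compound 2 share one core and differ in a single place: 3,5-dimethylphenyl in place of 4-chlorophenyl on a sulfur. This exchange moved the read-out by a number 2.4 percentage points higher from compound 2 to compound 1 (within the scatter). Compound 3 carries a different core; how the two cores differ is not broken down here. Its value lies beyond the scatter from that of compound 2, while the values of compound 3 and compound 1 are within the scatter of each other, so no order can be read between those two.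

Compound 4 `Cc1cc(C)cc(SCc2ccc(C(=O)Nc3ccccc3N)cc2)c1` is the unmeasured partner of compound 3. It differs from compound 3 exactly as compound 1 differs from compound 2: 3,5-dimethylphenyl in place of 4-chlorophenyl on a sulfur. The surroundings of the exchange read the same in both cases, so this is the same change made on the other core. Resting on the earlier step of a number 2.4 percentage points higher from compound 2 to compound 1 (within the scatter), a step of like size is expected for compound 4: a number 2.5 percentage points higher from compound 3 to compound 4 (within the scatter), within the scatter. Compound 4 is therefore expected to show 20% in this assay, with the likely range from 9% to 32%.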

Compound 4, percent growth inhibition at one concentration: 3.22%
For compound 4 the middle estimate is 16.8 percentage points above the measured one; measured number outside the range, below it.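

In this assay, the exchange of 4-chlorophenyl for 3,5-dimethylphenyl on a sulfur did not carry over from one core to the other, and the new step reads a number 14.3 percentage points lower from compound 3 to compound 4 (beyond the scatter). Set beside the earlier step, the two results differ: the same change on two cores in this assay, a number 2.4 percentage points higher (within the scatter) from compound 2 to compound 1 and a number 14.3 percentage points lower (beyond the scatter) from compound 3 to compound 4, 16.6 percentage points apart, beyond the scatter of two such steps. The size and direction of this change therefore depend on the core that carries it, but with a single pair on each core this shows neither why the two cores part ways nor how any other exchange would travel between them.

The compounds shown leave open whether the same gap between the cores would appear with other groups on the sulfur, such as an unsubstituted phenyl, a simple alkyl chain or a phenyl bearing an amine or a carboxylic acid. Also open, from the compounds shown here alone, is whether the difference between the cores would hold at other concentrations or in other cell lines.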